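Cytotoxicity in Skin Fibroblasts: From Compound 3 to Compound 4

The source may hold more compounds than are shown below. What is called first, only, known or untested is meant among the compounds shown, and "the series" means these compounds.

Compound 1, `CCc1ccc(-c2nc3c(c(C)nn3-c3ccccc3)c(-c3ccccc3Cl)c2C#N)cc1`, gives > 20000 nM in an ADME assay on BJ cells (Homo sapiens) for cytotoxicity, with a stated time of 72 h (on this read-out lower numbers stand for an effect already at smaller amounts and higher numbers for an effect only at larger amounts of compound), which is a limit of the assay and not a number.
Compound 2, `CCc1ccc(-c2nc3c(c(C)nn3-c3ccccc3)c(-c3cccc(O)c3)c2C#N)cc1`, gives > 20000 nM in this assay, again a limit.
Compound 3, `Cc1ccccc1-c1nc2c(c(C)nn2-c2ccccc2)c(-c2ccccc2O)c1C#N`, gives 21000 nM in this assay.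

Compound 3 is thus the only one of the three with a number of its own, and that number sits close to the limit of > 20000 nM in this assay, at which 2 of the 3 values shown sit, where the other two values stop. Going by the values given here, the one measured step that joins two compounds, a step that the two limits leave unreadable from compound 1 to compound 2, cannot be read as larger or smaller, so it gives no guide to the size of any effect in this assay.

Compound 4, `Cc1nn(-c2ccccc2)c2nc(-c3ccc(S(C)(=O)=O)cc3)c(C#N)c(-c3ccccc3O)c12`, differs from compound 3 by 4-(methylsulfonyl)phenyl in place of 2-methylphenyl on an aromatic carbon. Among the compounds with values here, no measured step concerns this change, and the single measured step in the set is itself unreadable. Within the data shown here, with every compound so far showing an effect only at the top of the tested range, the expectation for compound 4 is a step of a 1.2-fold higher number from compound 3 to compound 4 (0.08 log units; within the scatter) that stays within the scatter, and it may well again be reported only as a limit. Compound 4 is therefore estimated at 25000 nM, within a range from 10000 nM to 60000 nM.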

Compound 4, half-maximal effective concentration: > 20000 nM
Compound 4 ended at the assay's limit (the forecaster's own chance of this, stated with the estimate: 60%); the middle value is on the limit's open side.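

In this assay compound 4 gives > 20000 nM, which is a limit and not a number, so the step between compound 3 and compound 4 cannot be read. The compounds shown leave open whether any change to the groups on the shared core shifts the effect in this assay by a readable amount, with most values resting at one point: the limit of > 20000 nM in this assay, at which 3 of the 4 values shown sit.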